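Returning from phenoxy to benzyl with an isopropyl group

The source may report more compounds than this note shows. Statements on the series, on what has been measured and on what is new or still open speak of the compounds shown alone.

Compound 3 `CCn1nc(C)c2c1CCN([C@@H](C(=O)NC)c1ccccc1)[C@H]2COc1ccc(C)cc1` gives 10000 nM in a functional assay on CHO cells for antagonist activity at Orexin/Hypocretin receptor type 1 (Homo sapiens), read by FLIPR and calcium flux (on this read-out higher numbers stand for weaker inhibition and lower numbers for stronger inhibition), the highest number among the three measured compounds. Compound 1 `CCn1nc(C)c2c1CCN(C(C(=O)NC)c1ccccc1)C2CCc1ccc(Cl)cc1` gives 993 nM, and compound 2 `CCn1nc(C)c2c1CCN([C@@H](C(=O)NC)c1ccccc1)[C@H]2CCc1ccc(C(F)(F)F)cc1` gives 128 nM, so compound 3 stands well apart from both. The new compound 4 `CCn1nc(C)c2c1CCN([C@@H](C(=O)NC)c1ccccc1)[C@H]2CCc1ccc(C(C)C)cc1` differs from compound 3 in one place: 4-isopropylbenzyl in place of 4-methylphenoxy on a saturated chain carbon bound to a saturated ring carbon. For the measured compounds named here, the one measured step that bears on it is the reverse of this kind of change: a 78-fold higher number from compound 2 to compound 3 (1.89 log units; beyond the scatter). Compound 4 carries a benzyl group on that chain carbon again, as compound 2 does, with an isopropyl group on the aromatic ring rather than trifluoromethyl; nothing measured shows what that swap on the ring does by itself, so the estimate rests on the return of the benzyl linkage. The author therefore expects a large step downward, a 33-fold lower number from compound 3 to compound 4 (1.52 log units; beyond the scatter), and estimates that compound 4 should give about 300 nM in this assay, between 60 nM and 1500 nM.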

Compound 4, half-maximal inhibitory concentration: 161 nM
Compound 4: middle estimate off by 1.9-fold (0.27 log units), on the high side; the measured number falls inside the stated range.
By their numbers in this assay, from the lowest: compounds 2 and 4 (each within the scatter of the next); then compound 1; then compound 3.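

In this assay, isopropyl and trifluoromethyl on an aromatic carbon cannot be told apart, with a 1.3-fold higher number from compound 2 to compound 4 (0.10 log units; within the scatter), so a second, quite different group on the ring of the benzyl side chain gives a value within the scatter of the first. The large step, a 62-fold lower number from compound 3 to compound 4 (1.79 log units; beyond the scatter), now has a counterpart in the step of a 78-fold higher number from compound 2 to compound 3 (1.89 log units; beyond the scatter): with either ring group, the benzyl compounds stand far from the 4-methylphenoxy compound 3. Nothing shown here explains this gap.

The step from compound 3 to compound 4 changes the chain and the ring group together, so a 4-methylbenzyl group would be needed to separate the two. As far as these compounds go, whether an amine or a carboxylic acid on that aromatic carbon would fit the same picture also remains open.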